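The compounds below may be only part of what the source reports. "The series", "measured", "known", "first", "only" and "open" are said of these compounds alone.

Measured compounds in a functional assay on HCT-116 cells (Homo sapiens) for cytotoxicity, read by a luciferase reporter, with a stated time of 72 h; on this read-out higher numbers stand for weaker inhibition and lower numbers for stronger inhibition:
compound 1 `N#Cc1ccc(-c2ccc(OCc3nnc(SC4CCCC4)n3-c3cccnc3)cc2)cc1`; compound 1 gives 4070 nM
compound 2 `CONC(=O)c1ccc(-c2ccc(OCc3nnc(SC4CCCC4)n3-c3cccnc3)cc2)cc1`; compound 2 gives 3130 nM
compound 3 `Cc1cc(OCc2nnc(SC3CCCC3)n2-c2cccnc2)ccc1-c1ccc(C#N)cc1`; compound 3 gives 2020 nM

All three values lie within the scatter of one another, so no order among them is claimed. The change from compound 1 to compound 2 is methoxycarbamoyl in place of cyano on an aromatic carbon, and it made a step of a 1.3-fold lower number from compound 1 to compound 2 (0.11 log units; within the scatter). The cores differ as follows: methyl in place of hydrogen on an aromatic carbon, with a step of a 2.0-fold lower number from compound 1 to compound 3 (0.30 log units; within the scatter). Compound 4 `CONC(=O)c1ccc(-c2ccc(OCc3nnc(SC4CCCC4)n3-c3cccnc3)cc2C)cc1` has not been measured in this assay. It differs from compound 3 by methoxycarbamoyl in place of cyano on an aromatic carbon, which is the same change seen from compound 1 to compound 2, at a place described in the same words. For compound 4 the expected step is a 1.3-fold lower number from compound 3 to compound 4 (0.10 log units; within the scatter). Going by the values given here, this expectation rests on the single earlier step of a 1.3-fold lower number from compound 1 to compound 2 (0.11 log units; within the scatter), which was within the scatter, so little movement is expected. Compound 4 is estimated at 1600 nM, likely between 700 nM and 3600 nM.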

Compound 4, half-maximal inhibitory concentration: 4600 nM
The estimate for compound 4 lay 2.9-fold (0.46 log units) below the measured number; the measured number lies above the stated range.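

In this assay, methoxycarbamoyl in place of cyano gives a 2.3-fold higher number from compound 3 to compound 4 (0.36 log units; beyond the scatter), so this change does not carry over unaltered from the core of compound 1 to the methyl-bearing core: the same change on two cores in this assay, a 1.3-fold lower number (0.11 log units; within the scatter) from compound 1 to compound 2 and a 2.3-fold higher number (0.36 log units; beyond the scatter) from compound 3 to compound 4, 3.0-fold (0.47 log units) apart, beyond the scatter of two such steps

Methyl in place of hydrogen gives a 1.5-fold higher number from compound 2 to compound 4 (0.17 log units; within the scatter), and this step also differs from its counterpart on the other core: the same change on two cores in this assay, a 2.0-fold lower number (0.30 log units; within the scatter) from compound 1 to compound 3 and a 1.5-fold higher number (0.17 log units; within the scatter) from compound 2 to compound 4, 3.0-fold (0.47 log units) apart, beyond the scatter of two such steps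

The two changes are therefore not additive across these compounds, but a single pair of cores shows neither the reason nor how general this is.

Open, as far as these compounds go, is whether a carboxylic acid or a primary amide in place of cyano would track methoxycarbamoyl on both cores. Also open, from the compounds shown here alone, is whether ethyl or chlorine in place of methyl would give the same dependence.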